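From Butyl to Isobutyl Carbamate on a Shared Core

This account rests on a few compounds, and the source may have more. Where it says the series, first, only, none or still open, it means among the compounds named here.

Compound 2 `CCCCOC(=O)N1CCC(Oc2ncnc3c2CCN3c2ccc(S(C)(=O)=O)cc2F)CC1` carries a butoxycarbonyl group on the shared core, and in a functional assay on CHO-K1 cells for agonist activity at Glucose-dependent insulinotropic receptor (Homo sapiens), read by a luciferase reporter, with a stated time of 5 h (on this read-out higher numbers stand for an effect only at larger amounts of compound and lower numbers for an effect already at smaller amounts), compound 2 gives 50.1 nM. Compound 1 `CC(C)OC(=O)N1CCC(Oc2ncnc3c2CCN3c2ccc(S(C)(=O)=O)cc2F)CC1` bears an isopropyl group in place of the butyl chain, and in this assay compound 1 gives 50.1 nM. The step of no change at the digits printed from compound 1 to compound 2 (within the scatter) lay within the scatter. Compound 3 `CC(C)COC(=O)N1CCC(Oc2ncnc3c2CCN3c2ccc(S(C)(=O)=O)cc2F)CC1` has not yet been measured in this assay. It differs from compound 2 by isopropyl in place of propyl on a saturated chain carbon bound to an oxygen next to a carbonyl group. Among the compounds with values here, the one measured step that bears on this change, from compound 1 to compound 2, showed no shift beyond the scatter even though it exchanged a branched for an unbranched chain on the same oxygen. Compound 3 is therefore expected to show a step of a 1.0-fold lower number from compound 2 to compound 3 (0.00 log units; within the scatter) in this assay, that is, nothing beyond the scatter. The estimated value for compound 3 is 50 nM, with a range from 25 nM to 100 nM.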

Compound 3, half-maximal effective concentration: 25.1 nM
Beside the measured number, compound 3's estimate is 2.0-fold (0.30 log units) above it; measured number inside the range.
By their numbers in this assay, from the lowest: compounds 3, 1 and 2 (each within the scatter of the next).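

In this assay, isopropyl in place of propyl on a saturated chain carbon bound to an oxygen next to a carbonyl group gave a 2.0-fold lower number from compound 2 to compound 3 (0.30 log units; within the scatter), and isobutyl in place of isopropyl on an oxygen next to a carbonyl group gave a 2.0-fold lower number from compound 1 to compound 3 (0.30 log units; within the scatter). Compound 3 thus adds isobutyl to the butyl and isopropyl chains, and all three lie within the scatter of one another, so neither the presence of a branch nor the carbon that carries it separates these compounds on this read-out. Nothing measured here speaks to the reason for these values.

The compounds shown leave open whether a longer chain such as hexyl, a cyclopropylmethyl group or an amine on this oxygen would stay within the scatter of these three. They also leave open whether any group at this place can move the number in this assay beyond the scatter.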